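The source may hold more compounds than are shown below. What is called first, only, known or untested is meant among the compounds shown, and "the series" means these compounds.

The measured compounds in a functional assay for inhibition of sodium/hydrogen exchanger (Oryctolagus cuniculus) (on this read-out lower numbers stand for stronger inhibition and higher numbers for weaker inhibition), are:

compound 1, `CS(=O)(=O)c1cc(C(=O)N=C(N)N)c(F)cc1F` — 630 nM
compound 2, `Cc1c(C(=O)N=C(N)N)cc(S(C)(=O)=O)c(Cl)c1[N+](=O)[O-]` — 44 nM
compound 3, `Cc1cc(-c2ccc(Cl)cc2)c(S(C)(=O)=O)cc1C(=O)N=C(N)N` — 45 nM

Compound 3 stands second highest of the three numbers in this assay. Its nearest neighbour is compound 2, whose number is within the scatter of that of compound 3, so no order between the two can be claimed. Its furthest neighbour is compound 1, whose number lies well beyond the scatter and marks the weakest inhibition of the three.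

Compound 4, `Cc1cc(O)c(S(C)(=O)=O)cc1C(=O)N=C(N)N`, has not yet been measured in this assay. It differs from compound 3 in one place: hydroxy in place of 4-chlorophenyl on an aromatic carbon. A group of seven heavy atoms with one aromatic ring is thus replaced by a single oxygen bearing a donor and an acceptor.

For the measured compounds named here, no step between measured compounds that differ in one place is available, so the expectation rests on the spread of the three values. Compound 3 carries a 4-chlorophenyl and gives 45 nM, whereas compound 1, which carries no comparable substituent, gives 630 nM. On that basis a step of an 8.9-fold higher number from compound 3 to compound 4 (0.95 log units; beyond the scatter) toward weaker inhibition is expected for compound 4. Compound 4 is therefore estimated at 400 nM, with a range from 100 nM to 1600 nM.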

Compound 4, half-maximal inhibitory concentration: 220 nM
Estimate against measurement, compound 4: 1.8-fold (0.26 log units) above; low and high end bracket the measured number.
By their numbers in this assay, from the lowest: compounds 2 and 3 (each within the scatter of the next); then compound 4; then compound 1.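

In this assay, for the compounds shown here, the change at this position, ortho to the methylsulfonyl group and meta to the methyl group, can now be read on its own for the first time: hydroxy in place of 4-chlorophenyl is a step of a 4.9-fold higher number from compound 3 to compound 4 (0.69 log units; beyond the scatter) toward weaker inhibition. The earlier compounds shown here differ from one another in more than one place, so they could not isolate this substituent, whereas this pair shows that inhibition is weakened but not lost, with compound 4 still giving 220 nM on the shared core. No measurement at hand accounts for the step, and this single pair cannot separate the departure of the 4-chlorophenyl from the arrival of the hydroxy.

The compounds shown leave open whether a plain phenyl, without the chlorine, would stay close to compound 3, and whether a methoxy or an amine at this place would fall nearer compound 3 or compound 4. They also leave open whether the same change would give a step of similar size with a different set of neighbouring groups on the core.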